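Pyrazole ureas: hydroxy to methoxy on the chlorophenyl arm

A few compounds are considered here, and "the series" means these few. Any claim that something is new, unique, unknown or untested is made for them only; others in the source may bear on it.

Measured compounds:
compound 1, `O=C(Nc1cccc(-n2cc(-c3ccncc3)c(-c3cc(O)cc(Cl)c3)n2)c1)Nc1ccc(Cl)c(C(F)(F)F)c1`, 54%
compound 2, `O=C(Nc1cccc(-n2cc(-c3ccncc3)c(-c3cc(O)cc(Cl)c3)n2)c1)Nc1ccc(Cl)c(Cl)c1`, 63%
compound 3, `COc1cc(Cl)cc(-c2nn(-c3cccc(NC(=O)Nc4cc(C(F)(F)F)cc(C(F)(F)F)c4)c3)cc2-c2ccncc2)c1`, 48%

In a functional assay on SNB-75 cells (Homo sapiens) for inhibition, read by sulforhodamine B assay, with a stated time of 48 h, tested at 1 uM (on this read-out lower numbers stand for a stronger effect and higher numbers for a weaker effect at the one concentration tested), compound 2 gives the highest number of the three. Its nearest neighbour is compound 1, which is a number 9 percentage points higher from compound 1 to compound 2 (within the scatter), so these two cannot be told apart. For the measured compounds named here, compound 3, with 48%, stands further off below compound 2, a gap beyond the scatter; compound 3 differs from compound 2 in more than one place, so no single step between them is counted.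

Compound 4, `COc1cc(Cl)cc(-c2nn(-c3cccc(NC(=O)Nc4ccc(Cl)c(Cl)c4)c3)cc2-c2ccncc2)c1`, is not yet measured. It differs from compound 2 by methyl in place of hydrogen on an oxygen on an aromatic ring, that is, hydroxy becomes methoxy on the 3-chloro-5-hydroxyphenyl group, while the dichlorophenyl urea end is kept. Going by the values given here, no measured step bears on this change: the one counted step, a number 9 percentage points higher from compound 1 to compound 2 (within the scatter), concerns the urea end and not the oxygen. Compound 3 carries the methoxy, but its lower number cannot be assigned to the methyl alone because of the second difference at the urea end.

With no guidance from a matching step, no change beyond the scatter is expected, and the estimate for compound 4 is 58% in this assay, with a range of 44% to 72%, an expected step of a number 5 percentage points lower from compound 2 to compound 4 (within the scatter).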

Compound 4, a percentage reported as activity, at one concentration (the size of the read-out at that concentration, not a potency): 71%
Beside the measured number, compound 4's estimate is 13 percentage points below it; the range from low to high includes it.
By their numbers in this assay, from the lowest: compounds 3, 1, 2 and 4 (each within the scatter of the next, the first and the last beyond it).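

In this assay, for the compounds shown here, the pair that shares the dichlorophenyl urea end gives the first clean reading of this oxygen: methyl in place of hydrogen gives a number 8 percentage points higher from compound 2 to compound 4 (within the scatter) and so hydroxy to methoxy on the chlorophenyl arm produces no change that can be told from the scatter. The earlier compounds shown here could not show this, since compound 3 carries the methoxy but also differs from compound 2 at the urea end, which left the contribution of the methyl alone unread. No measurement of any property of these compounds is available to account for the result.

Whether hydroxy to methoxy reads the same with the other urea ends remains open, as compound 1 has no methoxy partner and compound 3 has no hydroxy partner among the compounds shown, and the reading rests on a single concentration in one cell line. Also open, from the compounds shown here alone, is how the position responds to larger or different groups, such as a longer chain like ethyl or a carboxylic acid on the oxygen, or an amine in place of the hydroxy.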